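Compound 1 to compound 4: a smaller group enters

This account rests on a few compounds, and the source may have more. Where it says the series, first, only, none or still open, it means among the compounds named here.

Compound 1 `CCn1nnc(-c2ccc(NC(=O)CSc3nnc(CNc4ccccc4)n3CC)cc2)n1` sits at a limit: in an assay on isolated protein for inhibition of long-chain fatty acid transport protein 1 (Mus musculus) (a lower number here means a stronger inhibitor, a higher number a weaker inhibitor), compound 1 gives > 10000 nM, which is a limit of the assay and not a number. Compound 2 `CCc1ccc2oc(CSc3nnc(CNc4ccccc4)n3CC)nc2c1` gives 1800 nM in this assay. Compound 3 `CC/C(=N/OC)c1ccc2oc(CSc3nnc(CNc4ccccc4)n3CC)nc2c1` also sits at a limit, giving > 10000 nM in this assay. For the measured compounds named here, the only measured step, an at least 5.5-fold higher number from compound 2 to compound 3 (0.74 log units; beyond the scatter), concerns a larger group replacing a smaller one on a different core, so it does not bear directly on the change below. Compound 4 `CCn1c(CNc2ccccc2)nnc1SCC(=O)Nc1ccc(Cl)cc1` differs from compound 1 by chloro in place of 2-ethyl-2H-tetrazol-5-yl on an aromatic carbon. Going by the values given here, no measured step covers this change, and compound 1 itself is one of the values sitting at the limit of > 10000 nM in this assay, at which 2 of the 3 values shown sit, so the starting point is open. The step in this assay is therefore expected to be modest and of uncertain direction, with a real chance that compound 4 again returns only the limit. Compound 4 is estimated at 6000 nM, within 1200 nM to 30000 nM, which would be expected to mean an at least 1.6-fold lower number from compound 1 to compound 4 (0.22 log units; that floor lies within the scatter).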

Compound 4, half-maximal inhibitory concentration: > 10000 nM
Compound 4 was reported as a limit (the forecaster's own chance of this, stated with the estimate: 45%); middle value at least 1.6-fold (0.22 log units) away from the limit.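

Compound 1 and compound 4 both sit at a limit in this assay, so the step between them, chloro in place of 2-ethyl-2H-tetrazol-5-yl, cannot be read. The compounds shown leave open which of these two groups gives the stronger inhibitor, and most values rest at one limit: the limit of > 10000 nM in this assay, at which 3 of the 4 values shown sit.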